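From phenyl to 4-methylphenyl in compound 2

The compounds below may be only part of what the source reports. "The series", "measured", "known", "first", "only" and "open" are said of these compounds alone.

In a functional assay on HCT-8 cells (Homo sapiens) for cytotoxicity (on this read-out higher numbers stand for an effect only at larger amounts of compound and lower numbers for an effect already at smaller amounts), two compounds have been measured so far. Compound 1 (`COC1=C(C)C(=O)/C(=C(O)/C=C/c2ccc(Br)cc2)C(=O)C1(C)C`) gives 7.4 ug/mL and compound 2 (`CCC1=C(OC)C(CC)(CC)C(=O)C(C(=O)/C=C/c2ccccc2)=C1O`) gives 3.7 ug/mL as its value. These two numbers lie within the scatter of each other, so compound 2 cannot be ranked apart from compound 1. Compound 3 (`CCC1=C(OC)C(CC)(CC)C(=O)C(C(=O)/C=C/c2ccc(C)cc2)=C1O`) has not yet been measured. It differs from compound 2 in one place, where the change methyl in place of hydrogen on an aromatic carbon puts methyl in place of hydrogen on an aromatic carbon, para to a large group, and turns phenyl to 4-methylphenyl. Within the data shown here, no two measured compounds differ in just one place, so the data offer no step to compare. A step in this assay beyond the scatter is not expected, and neither direction is favoured. For compound 3 the estimated value is 3.7 ug/mL with an expected range from 1.5 ug/mL to 9 ug/mL on this read-out.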

Compound 3, concentration for half-maximal effect: 9.4 ug/mL
Compound 3: middle estimate off by 2.5-fold (0.40 log units), on the low side; the measured number lies above the stated range.
By their numbers in this assay, from the lowest: compounds 2, 1 and 3 (each within the scatter of the next, the first and the last beyond it).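

Among these compounds, the change from phenyl to 4-methylphenyl gives the first step that can be read in this assay: a 2.5-fold higher number from compound 2 to compound 3 (0.40 log units; beyond the scatter). It shows that this place, on an aromatic carbon para to a large group, responds to a single added methyl, which shifts the effect to larger amounts of compound by a modest step. The data at hand offer nothing that would explain this step.

On these data alone, with one substitution at this place, it remains open whether the shift is specific to methyl or would also appear with a longer chain such as ethyl, a methoxy group or an amine. As far as these compounds go, it is equally open whether a group such as a carboxylic acid would move the number in the opposite direction, towards effects at smaller amounts.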